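Fluoro to hydrogen on the fused ring of compound 3

The source may hold more compounds than are shown below. What is called first, only, known or untested is meant among the compounds shown, and "the series" means these compounds.

Compound 1 `O=c1c(C(=S)Nc2ccccc2)coc2cc(Cl)ccc12` gives 66% in a functional assay on A549 cells (Homo sapiens) for inhibition, read by sulforhodamine B assay, with a stated time of 48 h, tested at 100 uM; a higher number here means more inhibition of growth at the concentration tested, a lower number less inhibition of growth. Compound 2 `O=c1c(C2N=C(c3ccccc3)SS2)coc2cc(Cl)c(Cl)cc12` gives 52% in this assay. Compound 3 `O=c1c(C2N=C(c3ccccc3)SS2)coc2ccc(F)cc12` gives 55% in this assay, the second highest of the three numbers; its gap to compound 2 lies within the scatter, its gap to compound 1 beyond it. Compound 4 `O=c1c(C2N=C(c3ccccc3)SS2)coc2ccccc12` differs from compound 3 by hydrogen in place of fluoro on an aromatic carbon. Among the compounds with values here, no pair of measured compounds shows this change, so the size of the step is open; the expectation is a step of no size beyond the scatter, if anything slightly downward. The step of a number 3 percentage points lower from compound 3 to compound 4 (within the scatter) is therefore expected to stay within the scatter. For compound 4 the estimate in this assay is 52%, with a range from 40% to 64%.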

Compound 4, percent growth inhibition at one concentration: 42%
For compound 4 the middle estimate is 10 percentage points above the measured one, within the range that was stated.
By their numbers in this assay, from the lowest: compounds 4, 2 and 3 (each within the scatter of the next, the first and the last beyond it); then compound 1.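

Putting hydrogen in place of fluoro on this aromatic carbon gives a number 13 percentage points lower from compound 3 to compound 4 (beyond the scatter) in this assay. Within the data shown here, this is the only comparison so far between compounds that differ in one place, and it shows that the number in this assay responds to the group at this position, which the earlier compounds could not show. Nothing available accounts for the size of the step.

Open, as far as these compounds go, is whether a methoxy group or an amine on this carbon would give a number nearer that of compound 3 or that of compound 4. Also open, from the compounds shown here alone, is whether the same change gives a step of similar size on the core of compound 1.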